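The compounds below may be only part of what the source reports. "The series", "measured", "known", "first", "only" and "open" are said of these compounds alone.

Compound 1 `Cc1ccccc1-c1nn(-c2ccc(Br)cc2)cc1CNCCN1CCN(C)CC1` gives the highest number of the three measured in an ADME assay on Huh-7 cells (Homo sapiens) for cytotoxicity (on this read-out higher numbers stand for lower toxicity in this test and lower numbers for higher toxicity in this test), at 9600 nM. Compound 2 `CN1CCN(CCNCc2cn(-c3ccc(C(F)(F)F)cc3)nc2-c2ccc(Cl)cc2)CC1` gives 3000 nM in this assay, and compound 3 `CCCN1CCC(CNCc2cn(-c3ccc(C(F)(F)F)cc3)nc2-c2ccc(Cl)cc2)CC1` gives 1900 nM; both differ from compound 1 in more than one place, so their gaps to compound 1 cannot be tied to a single change. Among the measured compounds shown here, the one single-point step recorded, a 1.6-fold lower number from compound 2 to compound 3 (0.20 log units; within the scatter), concerns the amine-bearing chain and not the group on the aromatic nitrogen.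

Compound 4 `Cc1ccc(-n2cc(CNCCN3CCN(C)CC3)c(-c3ccccc3C)n2)c(C)c1` differs from compound 1 by 2,4-dimethylphenyl in place of 4-bromophenyl on an aromatic nitrogen. For the measured compounds named here, no measured step varies the group on the aromatic nitrogen on its own, so nothing speaks for a shift in this assay beyond the scatter in either direction. The step is therefore expected to be a 1.2-fold lower number from compound 1 to compound 4 (0.08 log units; within the scatter), that is, no change beyond the scatter. Compound 4 is expected to give about 8000 nM in this assay, within a range from 3000 nM to 20000 nM.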

Compound 4, half-maximal cytotoxic concentration: > 20000 nM
Compound 4 gave a limit, no number; the forecaster's own chance of this, stated with the estimate: 10%; at least 2.5-fold (0.39 log units) between middle value and limit.
By their numbers in this assay, from the lowest: compounds 3 and 2 (each within the scatter of the next); then compound 1. At a limit, above all of these: compound 4.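

Putting 2,4-dimethylphenyl in place of 4-bromophenyl on an aromatic nitrogen gives an at least 2.0-fold higher number from compound 1 to compound 4 (0.31 log units; beyond the scatter), the first single-point step shown that lies beyond the scatter in this assay. The group at this position therefore affects this read-out, and the change goes towards lower toxicity in this test. Compound 4 stands at a limit and not at a number, so the step has a lower bound but no measured size: the limit of > 20000 nM in this assay, at which 1 of the 4 values shown sits.

The compounds shown do not separate the loss of the bromine from the entry of the two methyl groups. On these data alone, it remains open whether a 4-methylphenyl or 2-methylphenyl group on this nitrogen would give a similar shift, and whether the same change would carry over to the amine-bearing chain of compound 3.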